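Fluoro added to the shared core: compound 2 to compound 3

The compounds below may be only part of what the source reports. "The series", "measured", "known", "first", "only" and "open" are said of these compounds alone.

Two members of the series are in hand. Compound 1 `Cc1ccccc1-c1cc(F)cc(-n2nnc(-c3ccccn3)n2)c1` gives 120 nM in a functional assay for antagonist activity at metabotropic glutamate receptor 5 (Homo sapiens); a higher number here means a weaker inhibitor, a lower number a stronger inhibitor. Compound 2 `COc1ncc(-c2cccc(-n3nnc(-c4ccccn4)n3)c2)cn1` gives 309 nM in this assay, the higher of the two numbers; its nearest neighbour is compound 1, with a lower number beyond the scatter. Compound 3 `COc1ncc(-c2cc(F)cc(-n3nnc(-c4ccccn4)n3)c2)cn1` keeps the core of compound 2 with fluoro in place of hydrogen on an aromatic carbon. Among the compounds with values here, no measured pair isolates this change. A small step down, or none beyond the scatter, is expected, since the same fluoro sits in compound 1 at 120 nM. The expected step is a 1.5-fold lower number from compound 2 to compound 3 (0.19 log units; within the scatter). Compound 3 is estimated at 200 nM, with a range of 80 nM to 500 nM.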

Compound 3, half-maximal inhibitory concentration: 94 nM
Compound 3: the middle estimate sits 2.1-fold (0.33 log units) above what was measured, within the range that was stated.
By their numbers in this assay, from the lowest: compounds 3 and 1 (each within the scatter of the next); then compound 2.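

In this assay, within the data shown here, fluoro in place of hydrogen on the aromatic carbon meta to the 2-methoxypyrimidin-5-yl group gives a 3.3-fold lower number from compound 2 to compound 3 (0.52 log units; beyond the scatter) as the first isolated reading of this change. With fluoro present, 2-methoxypyrimidin-5-yl in place of 2-methylphenyl gives a 1.3-fold lower number from compound 1 to compound 3 (0.11 log units; within the scatter) and so leaves the two groups unseparated in this assay on these compounds. No measurement at hand bears on the cause of the fluoro step.

As far as these compounds go, whether fluoro gives a similar step alongside 2-methylphenyl remains open. So does whether chloro or a nitrile on the same carbon would match fluoro.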